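The compounds below may be only part of what the source reports. "The series", "measured", "known", "first", "only" and "open" are said of these compounds alone.

Series notes, cytotoxicity.

Measured so far:
- compound 1, `COC(=O)C1C(=O)C(C(=O)OC)[C@H](c2ccccn2)N(CCCCCCCC(=O)O)[C@@H]1c1ccccn1`: 33.8 uM
- compound 2, `C=CCN1[C@H](c2ccc([N+](=O)[O-])cc2)C(C(=O)OCC)C(=O)C(C(=O)OCC)[C@@H]1c1ccc([N+](=O)[O-])cc1`: > 100 uM
- compound 3, `COC(=O)C1C(=O)C(C(=O)OC)[C@H](c2cccc([N+](=O)[O-])c2)N(Cc2ccc(OC)cc2)[C@@H]1c1cccc([N+](=O)[O-])c1`: > 100 uM

Within the data shown here, in an ADME assay on J774.1 cells (Mus musculus) for cytotoxicity, with a stated time of 48 h (a higher number here means that more compound is needed for the effect, a lower number that less compound is needed), compound 1 gives 33.8 uM, the only numeric value so far. For compound 2 the reading is a limit of the assay, > 100 uM, not a number. Compound 3 likewise returns only a limit, > 100 uM. Compound 3 therefore stands at the limit of > 100 uM in this assay, at which 2 of the 3 values shown sit, and nothing more precise can be said of where it sits.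

Compound 4, `COC(=O)C1C(=O)C(C(=O)OC)[C@H](c2cccc([N+](=O)[O-])c2)N(Cc2ccc(Cl)cc2)[C@@H]1c1cccc([N+](=O)[O-])c1`, is the next entry. It differs from compound 3 in one place: chloro in place of methoxy on an aromatic carbon. Among the measured compounds shown here, no two measured compounds differ in a single place, so nothing shows what such an exchange does in this assay. Given that compound 3 sits at the limit, the step from compound 3 to compound 4 is expected to be small, a number no higher from compound 3 to compound 4 (the limit leaves the size open), most likely within the scatter, with only a modest chance of a move toward less compound needed. Compound 4 is estimated at 100 uM, within 40 uM to 250 uM, and quite possibly the assay will again report only a limit.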

Compound 4, concentration for half-maximal effect: 46.6 uM
Beside the measured number, compound 4's estimate is 2.1-fold (0.33 log units) above it; the range from low to high includes it.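

Within this assay, chloro in place of methoxy on an aromatic carbon, the change from 4-methoxybenzyl to 4-chlorobenzyl, gives an at least 2.1-fold lower number from compound 3 to compound 4 (0.33 log units; beyond the scatter). Among these compounds, this is the first single-place step, and it shows that a substituent on this ring, para to a large group, can bring the read-out down to a measurable number. The step starts from a limit, so it gives a bound rather than a full size: the limit of > 100 uM in this assay, at which 2 of the 4 values shown sit.

As far as these compounds go, it remains open whether the unsubstituted benzyl, or a fluoro, a trifluoromethyl or an amine at the same place, would read like chloro or like methoxy. Also open, from the compounds shown here alone, is whether the chloro exchange has the same effect when the other groups on the core differ.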